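A few compounds are considered here, and "the series" means these few. Any claim that something is new, unique, unknown or untested is made for them only; others in the source may bear on it.

Measured so far in a physicochemical assay for lipophilicity, at pH 7.4; on this read-out higher numbers stand for higher lipophilicity and lower numbers for lower lipophilicity:
compound 1 `CNC(=O)c1cc(C(=O)N[C@H]2[C@@H]3C[C@@H](O)C[C@@H]32)cc2c1OC[C@H]2c1ccccc1`: 2.9
compound 2 `CNC(=O)c1cc(C(N)=O)cc2c1OC[C@H]2c1ccccc1`: 2.7
compound 3 `CNC(=O)c1cc(C(=O)NC2CC2)cc2c1OC[C@H]2c1ccccc1`: 3.6

Compound 3 stands highest of the three. The unmeasured compound 4 `CNC(=O)c1cc(C(=O)NCCC[C@H]2OC[C@H](N)CO2)cc2c1OC[C@H]2c1ccccc1` differs from it on an amide-type nitrogen, where a group of 10 heavy atoms (7 carbon, 1 nitrogen, 2 oxygen; one six-membered non-aromatic ring with 2 hetero atoms) in place of a group of 3 heavy atoms (3 carbon; one three-membered non-aromatic ring of carbon only), on an amide-type nitrogen is the change. Three measured steps sit on that nitrogen. Cyclopropyl in place of hydrogen gives a number 0.90 log units higher from compound 2 to compound 3 (beyond the scatter) as a modest rise. Swapping the oxygen-bearing group for hydrogen gives a number 0.20 log units lower from compound 1 to compound 2 (within the scatter) and swapping it for cyclopropyl gives a number 0.70 log units higher from compound 1 to compound 3 (beyond the scatter) as another modest rise. Among the measured compounds shown here, no measured compound carries a six-membered non-aromatic ring with 2 hetero atoms, so the guidance is limited. Compound 1 at 2.9 carries oxygen in this group and sits under compound 3 at 3.6 in this assay, so a fall of at least similar size is expected. The expected change is a number 1.30 log units lower from compound 3 to compound 4 (beyond the scatter) as a downward step. Compound 4 is estimated at 2.3 with a range from 1.6 to 2.9 as the expected span.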

Compound 4, distribution coefficient: 2.6
The estimate for compound 4 lay 0.30 log units below the measured number, within the range that was stated.
By their numbers in this assay, from the lowest: compounds 4, 2 and 1 (each within the scatter of the next); then compound 3.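

In this assay, the new group on the amide-type nitrogen gives a number 1.00 log units lower from compound 3 to compound 4 (beyond the scatter), yet it gives a number 0.10 log units lower from compound 2 to compound 4 (within the scatter) and a number 0.30 log units lower from compound 1 to compound 4 (within the scatter). Group size therefore does not track the number here: a hydrogen atom, the group of 7 heavy atoms and the group of 10 heavy atoms sit together, and only compound 3, with cyclopropyl, stands apart. Nothing available explains this pattern.

On these data alone, it stays open how the number would respond if a hydroxyl or a carboxylic acid replaced the amine on the six-membered ring. A longer chain leading to that ring is also an open case.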